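The source may report more compounds than this note shows. Statements on the series, on what has been measured and on what is new or still open speak of the compounds shown alone.

Measured in a functional assay on A549 cells (Homo sapiens) for antiproliferative activity, read by sulforhodamine B assay, with a stated time of 48 h; a lower number here means a stronger inhibitor of growth, a higher number a weaker inhibitor of growth:
- compound 1 `CC(C)CCc1c(OCCCCCCC(=O)NO)ccc2ccc(=O)oc12` gives 660 nM
- compound 2 `CC(C)CCc1c(OCCCCCC(=O)NO)ccc2c1OC(=O)CC2` gives > 30000 nM (a limit of the assay, not a number)
- compound 3 `CC(C)CCc1c(OCCCCCC(=O)NO)ccc(CCC(=O)NO)c1O` gives 5410 nM

Compound 2 has no true number to start from, and it stands at the limit of > 30000 nM in this assay, at which 1 of the 3 values shown sits. The two other compounds do give numbers, so growth inhibition can be read for this family.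

Compound 4 `CC(C)CCc1c(OCCCCCCCC(=O)NO)ccc2c1OC(=O)CC2` is the next compound to consider. The change from compound 2 is 2-(hydroxycarbamoyl)ethyl in place of hydroxycarbamoyl on a saturated chain carbon, five bonds along the chain from an oxygen on an aromatic ring. In words, it carries 2-(hydroxycarbamoyl)ethyl in place of hydroxycarbamoyl on a saturated chain carbon, five bonds along the chain from an oxygen on an aromatic ring.

Going by the values given here, no measured pair isolates this change, so any forecast is loose. The nearest guide is compound 1, whose core and chain both differ from those of compound 2. Compound 1 reaches 660 nM. A change of chain could therefore bring a measurable number, though the reading may also stay at the limit.

The expected change is an at least 7.5-fold lower number from compound 2 to compound 4 (0.87 log units; beyond the scatter), in the direction of stronger growth inhibition in this assay and probably beyond the usual scatter. For compound 4 the estimated value is 4000 nM, with an expected range of 900 nM to 30000 nM.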

Compound 4, concentration for 50% growth inhibition: > 30000 nM
Compound 4 gave a limit, no number; the forecaster's own chance of this, stated with the estimate: 25%; middle value at least 7.5-fold (0.87 log units) away from the limit.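

Compound 4, like compound 2, gives only a limit and not a number in this assay, so the step between these two compounds cannot be read: the limit of > 30000 nM in this assay, at which 2 of the 4 values shown sit.

The compounds shown leave open whether any chain on the core of compound 2 gives a measurable value, and how far core and chain each shape the growth inhibition of compound 1.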